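This account rests on a few compounds, and the source may have more. Where it says the series, first, only, none or still open, it means among the compounds named here.

In a functional assay on HCT-116 cells (Homo sapiens) for antiproliferative activity, read by MTT assay, with a stated time of 48 h (on this read-out lower numbers stand for stronger inhibition of growth and higher numbers for weaker inhibition of growth), three compounds that share one core and differ only in the chain on the ring nitrogen have been measured. Compound 2, `CCCCCCN(Cc1ccc(C(=O)NO)cc1)c1ncc(-c2ccc(C)cc2)s1`, carries a hexyl chain and gives 4850 nM. Compound 1, `CCCCN(Cc1ccc(C(=O)NO)cc1)c1ncc(-c2ccc(C)cc2)s1`, with a butyl chain, gives 8780 nM. Compound 3, `Cc1ccc(-c2cnc(N(Cc3ccc(C(=O)NO)cc3)CC(C)C)s2)cc1`, with an isobutyl chain, gives 5900 nM. Compound 2 sits at the low end of the three numbers, but neither neighbour is separated from it beyond the scatter: the step of a 1.8-fold lower number from compound 1 to compound 2 (0.26 log units; within the scatter) and the step of a 1.2-fold higher number from compound 2 to compound 3 (0.09 log units; within the scatter) are both small.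

Compound 4, `CCCN(Cc1ccc(C(=O)NO)cc1)c1ncc(-c2ccc(C)cc2)s1`, is not yet measured. Compared with compound 2 the change is hydrogen in place of propyl on a saturated chain carbon, three bonds along the chain from a nitrogen on an aromatic ring, so the chain is cut back to propyl, shorter than in any measured compound. Going by the values given here, the only step that speaks to chain length is a 1.8-fold lower number from compound 1 to compound 2 (0.26 log units; within the scatter), where lengthening the chain gave a modestly lower number. Shortening it further might therefore be expected to raise the number slightly, though that step itself lay within the scatter, so no change beyond the scatter can be asserted.

Compound 4 is expected to give about 8500 nM, with a likely range from 4000 nM to 18000 nM. For compound 4 this estimate amounts to a step of a 1.8-fold higher number from compound 2 to compound 4 (0.24 log units; within the scatter).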

Compound 4, concentration for 50% growth inhibition: 5800 nM
For compound 4 the middle estimate is 1.5-fold (0.17 log units) above the measured one, and the stated range covers the measured number.
By their numbers in this assay, from the lowest: compounds 2, 4, 3 and 1 (each within the scatter of the next).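

Compound 4 takes the chain on the nitrogen down to propyl, and in this assay this shorter chain does not separate from any of the others: against the hexyl chain the step reads (a 1.2-fold higher number from compound 2 to compound 4 (0.08 log units; within the scatter)), against the isobutyl chain (a 1.0-fold lower number from compound 3 to compound 4 (0.01 log units; within the scatter)), and against the butyl chain (a 1.5-fold lower number from compound 1 to compound 4 (0.18 log units; within the scatter)). All three steps lie within the scatter, so across propyl, butyl, isobutyl and hexyl, neither the length of this chain nor its branching appears as a readable difference in growth inhibition. Going by these compounds alone, the earlier compounds offered only one small step from butyl to hexyl as a possible hint of a trend with chain length, and compound 4 gives that hint no support.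

No further data bear on why these four chains read alike. Still open, from the compounds shown here alone, is whether a group of another kind at this position, such as a chain ending in an amine or a carboxylic acid, a much longer chain such as decyl, or a short methyl, would move the number beyond the scatter.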